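A few compounds are considered here, and "the series" means these few. Any claim that something is new, unique, unknown or untested is made for them only; others in the source may bear on it.

Measured so far:
Compound 1, `CNC(=O)c1nnc2ccc(-c3ccc(COC)nc3)cc2c1N[C@@H](C)C1CCOCC1`: 5.8 uL/min
Compound 2, `Cc1cn(C)nc1[C@H](C)Nc1c(C(N)=O)nnc2ccc(-c3ccc(OCCCN(C)C)nc3)cc12`: 12 uL/min
Compound 3, `CNC(=O)c1nnc2ccc(-c3ccc(OCCCN(C)C)nc3)cc2c1N[C@@H](C)C1CCOCC1`: 5.7 uL/min

These numbers come from an ADME assay on cells (Hepatocyte, Rattus norvegicus) for metabolic stability, read by HPLC, with a stated time of 30 min, tested at 1 uM; on this read-out higher numbers stand for fast clearance and lower numbers for slow clearance. Compound 3 gives the lowest of the three, but it lies within the scatter of compound 1; only compound 2 stands beyond the scatter above it. Among the compounds with values here, the single measured step, a 1.0-fold lower number from compound 1 to compound 3 (0.01 log units; within the scatter), concerns a different part of the molecule and says nothing direct about the change now considered. Compound 4, `CNC(=O)c1nnc2ccc(-c3ccc(OCCCN(C)C)nc3)cc2c1N[C@@H](C)c1nn(C)cc1C`, differs from compound 3 by 1,4-dimethyl-1H-pyrazol-3-yl in place of oxan-4-yl on a saturated chain carbon bound to a nitrogen on an aromatic ring and a saturated chain carbon. The entering 1,4-dimethyl-1H-pyrazol-3-yl group is also present in compound 2, whose number stands beyond the scatter above that of compound 3. A modest rise is therefore expected, a 1.8-fold higher number from compound 3 to compound 4 (0.24 log units; within the scatter), and compound 4 is expected to give 10 uL/min (range 5 uL/min to 20 uL/min).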

Compound 4, intrinsic clearance in a liver preparation (reported as CLH), per the amount of preparation that the assay uses in the Hepatocyte assay: 6.7 uL/min
The estimate for compound 4 lay 1.5-fold (0.17 log units) above the measured number; low and high end bracket the measured number.
By their numbers in the Hepatocyte assay, from the lowest: compounds 3, 1, 4 and 2 (each within the scatter of the next, the first and the last beyond it).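

In the Hepatocyte assay, the exchange of oxan-4-yl for 1,4-dimethyl-1H-pyrazol-3-yl at this carbon (a 1.2-fold higher number from compound 3 to compound 4 (0.07 log units; within the scatter)) and the added methyl on the amide-type nitrogen (a 1.8-fold lower number from compound 2 to compound 4 (0.25 log units; within the scatter)) both stay within the scatter, so neither change separates these compounds. In a physicochemical assay for lipophilicity, using the shake flask method, measured as octanol-water partition, with a stated time of 30 min, at pH 7.4 (a lower number here means a more polar compound, a higher number a more lipophilic compound), compound 3 gives 2.3 and compound 4 gives 2.3 as well. No measured evidence accounts for these results.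

Going by these compounds, how an open-chain amine or a phenyl ring would behave at this carbon remains open. So does the effect of a longer chain on the amide-type nitrogen.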